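Adding an isobutyl group to a limit-bound compound

The compounds below may be only part of what the source reports. "The series", "measured", "known", "first", "only" and "open" are said of these compounds alone.

Measured so far in a functional assay on HepG2 cells (Homo sapiens) for antiproliferative activity, read by sulforhodamine B assay, with a stated time of 72 h (a higher number here means a weaker inhibitor, a lower number a stronger inhibitor), for antiproliferative activity, each value being a limit of the assay:
- compound 1 `C[C@@H](NC(=O)OC(C)(C)C)C(=O)Nc1ccc2ncnc(Nc3ccc(F)c(Cl)c3)c2c1` gives > 50000 nM as a limit
- compound 2 `CC(C)[C@@H](NC(=O)OC(C)(C)C)C(=O)Nc1ccc2ncnc(Nc3ccc(F)c(Cl)c3)c2c1` gives > 50000 nM as a limit
- compound 3 `CC(C)(C)OC(=O)NCC(=O)Nc1ccc2ncnc(Nc3cccc(C(F)(F)F)c3)c2c1` gives > 50000 nM as a limit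

In this assay compound 3 has only a limit, > 50000 nM and no exact number. So far the data offer only the limit of > 50000 nM in this assay, at which 3 of the 3 values shown sit, and no exact value to compare.

Compound 4 `CC(C)C[C@@H](NC(=O)OC(C)(C)C)C(=O)Nc1ccc2ncnc(Nc3cccc(C(F)(F)F)c3)c2c1` differs from compound 3 in one place: isobutyl in place of hydrogen on a saturated chain carbon bound to an amide-type nitrogen and a carbonyl carbon.

Among the compounds with values here, one measured step touches that kind of carbon: a step that the two limits leave unreadable from compound 1 to compound 2 in which isopropyl replaces methyl. Its size cannot be read, so it gives no direction. With no readable step to lean on, no change beyond the usual scatter can be expected in this assay and compound 4 may well be reported as a limit too. The expected change is a number no higher from compound 3 to compound 4 (the limit leaves the size open) as a rough estimate. For compound 4 the estimated value is 50000 nM with an expected range from 20000 nM to 100000 nM overall.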

Compound 4, half-maximal inhibitory concentration: > 50000 nM
Compound 4 ended at the assay's limit (the forecaster's own chance of this, stated with the estimate: 70%); the middle value sits exactly at the limit.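

Compound 4, like compound 3, is reported only as a limit in this assay, so the step between them cannot be read, and neither can the earlier one between compound 1 and compound 2. All four compounds share one ceiling: the limit of > 50000 nM in this assay, at which 4 of the 4 values shown sit.

What the compounds shown leave open is whether any chain group at this carbon changes antiproliferative activity, since no exact value exists to compare.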